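Replacing an Oxazole with a Thiazole on the Amide Nitrogen

The compounds below may be only part of what the source reports. "The series", "measured", "known", "first", "only" and "open" are said of these compounds alone.

Compound 1 `CCOC(=O)c1sc(NC(=O)Cn2cc(-c3ccc(F)cc3)nn2)nc1C` carries a 4-methyl-1,3-thiazol-2-yl group on its amide-type nitrogen, and in a functional assay on BMDM cells (Mus musculus, strain C57BL/6) for inhibition, with a stated time of 2 days (on this read-out lower numbers stand for stronger inhibition and higher numbers for weaker inhibition), compound 1 gives 660 nM. Compound 2 `Cc1csc(NC(=O)Cn2cc(-c3ccccc3Cl)nn2)n1` also carries a 4-methyl-1,3-thiazol-2-yl group there but differs elsewhere in the shared core; in this assay compound 2 gives 1240 nM. Compound 3 `Cc1cc(NC(=O)Cn2cc(-c3ccc(F)cc3)nn2)no1` instead bears a 5-methyl-1,2-oxazol-3-yl group on that nitrogen. For compound 3 this assay reports only a limit, > 30000 nM, so no number is known for it. That value is the one of the three that sits at the limit of > 30000 nM in this assay, at which 1 of the 3 values shown sits.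

Compound 4 `Cc1csc(NC(=O)Cn2cc(-c3ccc(F)cc3)nn2)n1` differs from compound 3 in one place: 4-methyl-1,3-thiazol-2-yl in place of 5-methyl-1,2-oxazol-3-yl on an amide-type nitrogen. For the measured compounds named here, no measured pair in this set differs in exactly that way, so the size of the step has to be judged from what the thiazole-bearing compounds show. Compound 1 and compound 2 both carry a 4-methyl-1,3-thiazol-2-yl group and both give numbers rather than limits. Compound 4 is therefore expected to gain potency on leaving compound 3, a step that is estimated as an at least 30-fold lower number from compound 3 to compound 4 (1.47 log units; beyond the scatter), well beyond the scatter. Compound 4 is estimated at 1000 nM, with a range from 300 nM to 4000 nM.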

Compound 4, half-maximal inhibitory concentration: 250 nM
Estimate against measurement, compound 4: 4.0-fold (0.60 log units) above, and the stated range ends above it.
By their numbers in this assay, from the lowest: compound 4; then compounds 1 and 2 (each within the scatter of the next). At a limit, above all of these: compound 3.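

For the compounds shown here, compound 4 gives the first reading of this position that changes one place only: with 4-methyl-1,3-thiazol-2-yl in place of 5-methyl-1,2-oxazol-3-yl on an amide-type nitrogen, this assay shows an at least 120-fold lower number from compound 3 to compound 4 (2.07 log units; beyond the scatter) and this is the largest step in the set. Going by these compounds, compound 3 stands only at a limit of the assay, so the true size of that step remains unknown: the limit of > 30000 nM in this assay, at which 1 of the 4 values shown sits. Two other changes can now be read among the thiazole-bearing compounds and both are modest: hydrogen in place of ethoxycarbonyl on an aromatic carbon gives a 2.6-fold lower number from compound 1 to compound 4 (0.42 log units; beyond the scatter) and 4-fluorophenyl in place of 2-chlorophenyl on an aromatic carbon gives a 5.0-fold lower number from compound 2 to compound 4 (0.70 log units; beyond the scatter).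

On these data alone, the exchange of the two rings is read on one background only, the one carrying 4-fluorophenyl, so whether it holds with other groups stays open. Also open, as far as these compounds go, is how a carboxylic acid or an amine on the aromatic carbon that carries ethoxycarbonyl in compound 1 would read in this assay.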